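Methyl in place of hydrogen on the alcohol of compound 2

This account rests on a few compounds, and the source may have more. Where it says the series, first, only, none or still open, it means among the compounds named here.

Of the compounds shown here, three have been measured in an assay on isolated protein for inhibition of MAP kinase-interacting serine/threonine-protein kinase 1 (Homo sapiens); on this read-out lower numbers stand for stronger inhibition and higher numbers for weaker inhibition. Compound 1 `CNc1cc2c(Nc3cccc(Br)c3)ncnc2cn1` gives 1700 nM. Compound 2 `OCCNc1ccc2ncc(-c3ccc(Cl)cc3)n2n1` gives 2930 nM, the highest number of the three; the gap to compound 1 lies within the usual scatter, so the two cannot be told apart, whereas compound 3 `c1ccc2cc(Nc3ncnc4[nH]ncc34)ccc2c1` gives 1350 nM, a lower number by a gap that lies beyond the scatter. For the measured compounds named here, no pair among the measured compounds differs in a single place, so no step can be drawn from them.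

Compound 4 `COCCNc1ccc2ncc(-c3ccc(Cl)cc3)n2n1` is the next compound to be measured. It differs from compound 2 in one place: methyl in place of hydrogen on an oxygen on a saturated carbon. Going by the values given here, nothing among the measured compounds shows what this change does. The expectation is therefore that the step from compound 2 to compound 4 stays close to zero, in either direction, and does not reach beyond the scatter. Compound 4 is expected to give about 3000 nM in this assay, with a range from 1200 nM to 7500 nM, which corresponds to an expected step of a 1.0-fold higher number from compound 2 to compound 4 (0.01 log units; within the scatter).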

Compound 4, half-maximal inhibitory concentration: 1620 nM
The estimate for compound 4 lay 1.9-fold (0.27 log units) above the measured number; the measured number falls inside the stated range.
By their numbers in this assay, from the lowest: compounds 3, 4, 1 and 2 (each within the scatter of the next, the first and the last beyond it).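

In this assay the change from 2-hydroxyethyl to 2-methoxyethyl gives a 1.8-fold lower number from compound 2 to compound 4 (0.26 log units; within the scatter) and is the first single-place step available among these compounds. The two compounds cannot be told apart, so on this read-out the hydrogen on this oxygen can be replaced by methyl without any change that stands clear of the scatter. No measurement at hand explains this outcome.

What the compounds shown leave open is whether this position accepts more than a single added carbon, as a longer chain such as 2-ethoxyethyl would show, or whether an amine or a carboxylic acid in place of the hydroxy would leave the number just as unchanged. They also leave open whether removing the oxygen altogether, as in a plain propyl chain, would matter.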